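Chloro to Methoxy on the Benzylidene-Side Ring: What to Expect

The source may report more compounds than this note shows. Statements on the series, on what has been measured and on what is new or still open speak of the compounds shown alone.

Compound 1, `N#C/C(=C\c1ccccc1)C(=O)NCc1ccc(Cl)c(Cl)c1`, gives 43000 nM in a functional assay on A-431 cells (Homo sapiens) for inhibition, read by MTT assay, with a stated time of 72 h; a higher number here means a weaker inhibitor of growth, a lower number a stronger inhibitor of growth.
Compound 2, `N#C/C(=C\c1ccc(Cl)cc1)C(=O)NCc1ccc(Cl)c(Cl)c1`, gives 30000 nM in this assay.

Compound 2 sits beside compound 1 rather than apart from it: the step of a 1.4-fold lower number from compound 1 to compound 2 (0.16 log units; within the scatter) lies within the scatter, so the two compounds cannot be told apart on these numbers.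

Compound 3, `COc1ccc(/C=C(\C#N)C(=O)NCc2ccc(Cl)c(Cl)c2)cc1`, has not been measured. It differs from compound 2 in a single place: methoxy in place of chloro on an aromatic carbon. Within the data shown here, the only measured step, a 1.4-fold lower number from compound 1 to compound 2 (0.16 log units; within the scatter), touched this same carbon and stayed within the scatter, and no measured step involves a methoxy group at all. With so little to go on, compound 3 is expected to show no step beyond the scatter, no change at the digits printed from compound 2 to compound 3 (within the scatter) in this assay. The estimate for compound 3 is 30000 nM, with a range from 12000 nM to 75000 nM.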

Compound 3, concentration for 50% growth inhibition: 90000 nM
Compound 3: middle estimate off by 3.0-fold (0.48 log units), on the low side; the whole stated range lies below it.
By their numbers in this assay, from the lowest: compounds 2 and 1 (each within the scatter of the next); then compound 3.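

This carbon is not indifferent to what it carries. In this assay, among these compounds, methoxy gives the first change here that lies beyond the scatter, with the step of a 3.0-fold higher number from compound 2 to compound 3 (0.48 log units; beyond the scatter), and it also separates from plain hydrogen, with the step of a 2.1-fold higher number from compound 1 to compound 3 (0.32 log units; beyond the scatter), while chloro in place of hydrogen stayed within the scatter; in both steps methoxy gives the weaker inhibitor of growth, though only modestly. Nothing measured here explains why methoxy and chloro differ on this carbon.

The compounds shown leave open how an amine, a carboxylic acid or a longer chain such as ethoxy would behave at this spot. They also leave open whether any group on this carbon can give a clearly stronger inhibitor of growth than hydrogen or chloro.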